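Trading a methoxybenzyl amide for a chlorobenzyl methylamide

A few compounds are considered here, and "the series" means these few. Any claim that something is new, unique, unknown or untested is made for them only; others in the source may bear on it.

Measured so far:
- compound 1, `CCN(Cc1ccccc1)C(=O)c1nn(-c2ccc(F)cc2)c(OC[C@@H](O)C[C@@H](O)CC(=O)O)c1C(C)C`: 14 nM
- compound 2, `Cc1ccccc1CNC(=O)c1nn(-c2ccc(F)cc2)c(OC[C@@H](O)C[C@@H](O)CC(=O)O)c1C(C)C`: 17 nM
- compound 3, `COc1cccc(CNC(=O)c2nn(-c3ccc(F)cc3)c(OC[C@@H](O)C[C@@H](O)CC(=O)O)c2C(C)C)c1`: 16 nM

In an assay on microsomes from liver for inhibition of 3-hydroxy-3-methylglutaryl-coenzyme A reductase (Rattus norvegicus) (a lower number here means a stronger inhibitor, a higher number a weaker inhibitor), compound 3 gives 16 nM, which places it second highest of the three numbers; its nearest neighbour is compound 2 and its furthest is compound 1, and both of those gaps fall within the scatter, so the three compounds cannot be told apart on these numbers.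

Compound 4, `CC(C)c1c(C(=O)N(C)Cc2cccc(Cl)c2)nn(-c2ccc(F)cc2)c1OC[C@@H](O)C[C@@H](O)CC(=O)O`, is not yet measured. It differs from compound 3 by (3-chlorobenzyl)(methyl)amino in place of (3-methoxybenzyl)amino on a carbonyl carbon. Two features change at once: the hydrogen-bond donor on the nitrogen disappears, and a chlorine takes the place of the methoxy group on the aromatic ring.

Both parts have a precedent among the measured steps. Compound 1 already carries a nitrogen without a hydrogen, and a 1.1-fold higher number from compound 1 to compound 3 (0.06 log units; within the scatter) shows that adding the hydrogen back, together with the methoxy group, changed nothing beyond the scatter. Likewise a 1.1-fold lower number from compound 2 to compound 3 (0.03 log units; within the scatter) shows that swapping one ring substituent for another left the number where it was. Neither step hints at a direction for compound 4, so the expectation is no step beyond the scatter.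

Compound 4 is therefore estimated at 14 nM, with a likely range of 7 nM to 30 nM, an expected step of a 1.1-fold lower number from compound 3 to compound 4 (0.06 log units; within the scatter).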

Compound 4, half-maximal inhibitory concentration: 8.3 nM
Beside the measured number, compound 4's estimate is 1.7-fold (0.23 log units) above it; the range from low to high includes it.
By their numbers in this assay, from the lowest: compounds 4, 1, 3 and 2 (each within the scatter of the next, the first and the last beyond it).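

In this assay, this change gives the first step beyond the scatter among these compounds, a 2.0-fold lower number from compound 2 to compound 4 (0.31 log units; beyond the scatter), so swapping the group on the carbonyl carbon can move the number here, though only modestly. The other two comparisons, a 1.9-fold lower number from compound 3 to compound 4 (0.29 log units; within the scatter) and a 1.7-fold lower number from compound 1 to compound 4 (0.23 log units; within the scatter), remain within the scatter, so compound 4 cannot be told apart from compound 3 or compound 1, and it stands clear only of compound 2. Nothing shown here gives a reason for the step to compound 4.

The swap from compound 3 to compound 4 changes the ring substituent and the amide nitrogen together, so these compounds do not show how each change acts alone; a (3-chlorobenzyl)amino group that keeps the amide hydrogen, or a (3-methoxybenzyl)(methyl)amino group, would separate the two. Going by these compounds, it also remains open how the number responds to quite different groups on the benzyl ring, such as an amine or a carboxylic acid, or to a longer chain between the ring and the amide nitrogen.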